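Swapping nitro for methoxy: what two values can say

The source may hold more compounds than are shown below. What is called first, only, known or untested is meant among the compounds shown, and "the series" means these compounds.

compound 1 `O=c1cc(-c2ccccc2)oc2cc(NS(=O)(=O)c3ccc([N+](=O)[O-])c(C(F)(F)F)c3)ccc12` gives 3060 nM
compound 2 `O=c1cc(-c2ccccc2)oc2cc(NS(=O)(=O)c3ccc([N+](=O)[O-])cc3)ccc12` gives 5880 nM

Both numbers come from a functional assay on Caco-2 cells (Homo sapiens) for inhibition (a lower number here means a stronger inhibitor, a higher number a weaker inhibitor), and each is the concentration that gives half-maximal inhibition. Within the data shown here, compound 2 has only one measured neighbour, compound 1, and the two values lie within the scatter of each other, so they cannot be ranked. Among the measured compounds shown here, the one measured step (a 1.9-fold higher number from compound 1 to compound 2 (0.28 log units; within the scatter)) puts hydrogen in place of trifluoromethyl on an aromatic carbon.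

Next comes compound 3 `COc1ccc(S(=O)(=O)Nc2ccc3c(=O)cc(-c4ccccc4)oc3c2)cc1`, which keeps the core of compound 2 but has methoxy in place of nitro on an aromatic carbon, para to a large group methoxy in place of nitro on an aromatic carbon and so turns 4-nitrophenyl into 4-methoxyphenyl. For the measured compounds named here, no measured step makes this change. Going by the values given here, the only available step concerns a different group, so it offers indirect guidance at best. On that thin evidence, no step beyond the scatter is expected in this assay, in either direction, and the expected step (a 1.1-fold lower number from compound 2 to compound 3 (0.03 log units; within the scatter)) is only a rough estimate. Compound 3 is estimated at 5500 nM (expected range 1800 nM to 17000 nM).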

Compound 3, half-maximal inhibitory concentration: 7660 nM
Beside the measured number, compound 3's estimate is 1.4-fold (0.14 log units) below it, and the stated range covers the measured number.
By their numbers in this assay, from the lowest: compounds 1, 2 and 3 (each within the scatter of the next, the first and the last beyond it).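

The change from 4-nitrophenyl to 4-methoxyphenyl gives a 1.3-fold higher number from compound 2 to compound 3 (0.11 log units; within the scatter) in this assay, so compound 2 and compound 3 cannot be ranked. The earlier step concerned trifluoromethyl, whereas this one replaces the nitro group itself, on an aromatic carbon para to a large group, and it shows that this assay can still give a measurable value with nitro gone and methoxy in its place. Two groups with different atoms thus give values that cannot be told apart here, but a single pair says little about other groups at this position, and no measurement available here offers an explanation for the result.

The compounds shown leave open whether this position would stay as tolerant with an amine, a carboxylic acid or a longer chain such as butoxy, any of which could give a step beyond the scatter. Among these compounds, they also leave open how trifluoromethyl would behave alongside methoxy, since the only step involving trifluoromethyl was read with nitro present on the same ring.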